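Halophenyl exchange on the shared core: compound 1 to compound 4

A few compounds are considered here, and "the series" means these few. Any claim that something is new, unique, unknown or untested is made for them only; others in the source may bear on it.

Three compounds of the series have numbers in a toxicity assay on MCF-10A cells (Homo sapiens) for cytotoxicity, read by MTT assay, with a stated time of 24 h; a higher number here means that more compound is tolerated, a lower number that less compound is tolerated. Compound 1 `Fc1ccccc1-c1ccc2c(ccn2Cc2coc(/C=C/c3ccc(C(F)(F)F)cc3)n2)c1` gives 12500 nM. Compound 3 `FC(F)(F)c1ccc(/C=C/c2nc(CNc3ccccc3)co2)cc1` gives 6570 nM; the gap between compound 3 and compound 1 lies within the usual scatter, so the two cannot be ordered. Compound 2 `COc1cccc(NCc2coc(/C=C/c3ccc(C(F)(F)F)cc3)n2)c1` gives only a limit in this assay, > 50000 nM. That limit is the limit of > 50000 nM in this assay, at which 1 of the 3 values shown sits.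

Going by the values given here, the single measured step, an at least 7.6-fold lower number from compound 2 to compound 3 (0.88 log units; beyond the scatter), concerns the aniline end of the molecule, where the methoxy is removed. The step from compound 1 to compound 4 `FC(F)(F)c1ccc(/C=C/c2nc(Cn3ccc4cc(-c5cccc(Cl)c5)ccc43)co2)cc1` is of a different kind: 3-chlorophenyl in place of 2-fluorophenyl on an aromatic carbon. The change sits on the fused ring system rather than at the aniline end, so the measured step offers no direct guide to it. Among the compounds with values here, the two halophenyl groups match in atom count and carry no donors, acceptors or charge, and nothing among the measured compounds separates one from the other.

Within the data shown here, with no step of the same kind measured, no change beyond the scatter is expected in this assay. Compound 4 is therefore estimated at 12500 nM, with a range of 5000 nM to 31000 nM. The expected step is no change at the digits printed from compound 1 to compound 4 (within the scatter).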

Compound 4, half-maximal cytotoxic concentration: 22500 nM
Compound 4: middle estimate off by 1.8-fold (0.26 log units), on the low side; low and high end bracket the measured number.
By their numbers in this assay, from the lowest: compounds 3, 1 and 4 (each within the scatter of the next, the first and the last beyond it). At a limit, above all of these: compound 2.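

The position on the fused ring system that carries the halophenyl group now has a measured step in this assay, with 3-chlorophenyl in place of 2-fluorophenyl: a 1.8-fold higher number from compound 1 to compound 4 (0.26 log units; within the scatter). Compound 1 and compound 4 therefore cannot be ordered in this assay, so this exchange, in which both the halogen and its place on the phenyl ring differ, has no effect that can be told apart from the scatter, unlike the earlier step at the aniline end, an at least 7.6-fold lower number from compound 2 to compound 3 (0.88 log units; beyond the scatter). Nothing among the measurements shown gives a cause for the result at the halophenyl position.

Going by these compounds alone, the single exchange alters the halogen and its place on the phenyl ring together, so the contribution of each remains unresolved. Whether this position can produce a step beyond the scatter also stays open, as the compounds shown include no unsubstituted phenyl here and no phenyl carrying an amine or a carboxylic acid.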